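Adding a Methoxy Group to a Chalcone Core

The compounds below may be only part of what the source reports. "The series", "measured", "known", "first", "only" and "open" are said of these compounds alone.

Measured compounds:
compound 1, `COc1ccc(/C=C/C(=O)c2c(OC)cc(O)c(CC=C(C)C)c2O)cc1OC`, 27700 nM
compound 2, `COc1cc(/C=C/C(=O)c2c(OC)cc(O)c(CC=C(C)C)c2O)cc(OC)c1OC`, a limit of the assay rather than a number: > 50000 nM
compound 3, `COc1cc(/C=C/C(=O)c2c(OC)cc(OC)cc2OC)cc(OC)c1`, 9200 nM

All three were tested in a functional assay on HeLa cells (Homo sapiens) for inhibition, read by MTT assay, with a stated time of 72 h; a higher number here means a weaker inhibitor, a lower number a stronger inhibitor. Among the two numbers, compound 3 has the lowest, and its gap to compound 1 lies beyond the scatter. The difference between the cores of compound 1 and compound 3 is not broken down here.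

Compound 4, `COc1cc(OC)c(C(=O)/C=C/c2cc(OC)c(OC)c(OC)c2)c(OC)c1`, has not been measured. It differs from compound 3 by methoxy in place of hydrogen on an aromatic carbon. The same kind of change, (methoxy in place of hydrogen on an aromatic carbon), runs from compound 1 to compound 2 and gave an at least 1.8-fold higher number from compound 1 to compound 2 (0.25 log units; that floor lies within the scatter); that step is known only as a floor because of the limit of > 50000 nM in this assay, at which 1 of the 3 values shown sits. The surroundings differ: in compound 4 the new methoxy sits ortho to two methoxy groups and para to a large group, whereas in compound 2 it sits ortho to one methoxy, meta to a large group and meta to a methoxy group.

Resting on the weakening seen from compound 1 to compound 2, an at least 1.8-fold higher number from compound 1 to compound 2 (0.25 log units; that floor lies within the scatter), a modest step toward a higher number is expected, a 1.6-fold higher number from compound 3 to compound 4 (0.21 log units; within the scatter). Compound 4 is estimated at 15000 nM, within 5000 nM to 45000 nM.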

Compound 4, half-maximal inhibitory concentration: 9900 nM
Compound 4: the middle estimate sits 1.5-fold (0.18 log units) above what was measured; the measured number falls inside the stated range.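

In this assay, the methoxy group placed on the core of compound 3 gives a 1.1-fold higher number from compound 3 to compound 4 (0.03 log units; within the scatter), so the two compounds cannot be told apart. Set beside the earlier step on the core of compound 1, the comparison stays unsettled: the same change on two cores in this assay, an at least 1.8-fold higher number (0.25 log units; that floor lies within the scatter) from compound 1 to compound 2 and a 1.1-fold higher number (0.03 log units; within the scatter) from compound 3 to compound 4; the limit leaves it open whether they differ Compound 2 stands at > 50000 nM, which is a limit of the assay and not a number, so this pair of steps shows neither that the change carries over unaltered from one core to the other nor that it behaves differently on each.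

The compounds shown leave open whether another group on the same aromatic carbon, such as an amine, a carboxylic acid or a longer chain, would move the number on either core. They also leave open which part of the difference between the core of compound 1 and the core of compound 3 accounts for the gap between their numbers.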